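This account rests on a few compounds, and the source may have more. Where it says the series, first, only, none or still open, it means among the compounds named here.

Measured so far in an assay on isolated protein for inhibition of acyl-CoA desaturase 1 (Rattus norvegicus); a lower number here means a stronger inhibitor, a higher number a weaker inhibitor:
compound 1 `CS(=O)(=O)c1ccc2nc(-c3ccc(-c4ccccc4)cc3)[nH]c2c1` gives 20 nM
compound 2 `CS(=O)(=O)c1ccc2nc(-c3ccc(-c4ccc(Cl)cc4)cc3)[nH]c2c1` gives > 20000 nM, which is a limit of the assay and not a number

For the measured compounds named here, compound 2 stands at that limit (the limit of > 20000 nM in this assay, at which 1 of the 2 values shown sits); the step of an at least 1000-fold higher number from compound 1 to compound 2 (3.00 log units; beyond the scatter) is the only measured step bearing on the next change. Compound 3 `CS(=O)(=O)c1ccc2nc(-c3ccc(-c4ccc(F)cc4)cc3)[nH]c2c1` differs from compound 2 by fluoro in place of chloro on an aromatic carbon. With one halogen replacing another at the same place, the large loss seen from compound 1 to compound 2 is expected to be partly recovered, so a fall in this assay is estimated, an at least 13-fold lower number from compound 2 to compound 3 (1.12 log units; beyond the scatter), though the outcome may again be only a limit. Compound 3 is estimated at 1500 nM, between 100 nM and 20000 nM.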

Compound 3, half-maximal inhibitory concentration: 25 nM
Compound 3: middle estimate off by 60-fold (1.78 log units), on the high side, and the stated range ends above it.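

In this assay the change of hydrogen to fluoro reads a 1.3-fold higher number from compound 1 to compound 3 (0.10 log units; within the scatter), so a halogen at this place, para to a large group, is tolerated when it is fluoro. The step of an at least 800-fold lower number from compound 2 to compound 3 (2.90 log units; beyond the scatter) shows that the outcome here turns on which halogen is present, and that the loss belongs to chloro rather than to any replacement of hydrogen. That step is open-ended, with compound 2 at a limit of the assay and not a number: the limit of > 20000 nM in this assay, at which 1 of the 3 values shown sits.

On these data alone, whether methyl, methoxy or bromo at this place behaves like chloro or like fluoro remains open. So does whether an amine or a carboxylic acid is accepted here.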